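Swapping the aryl cap on a piperazine nitrogen

The source may report more compounds than this note shows. Statements on the series, on what has been measured and on what is new or still open speak of the compounds shown alone.

Compound 1 `COC(=O)CC/C(C)=C/Cc1c(OC)c(C)c2c(c1OCC#CCN1CCN(c3ccc(C)cc3)CC1)C(=O)OC2` was tested in a functional assay on HT-29 cells (Homo sapiens) for inhibition, read by sulforhodamine B assay; on this read-out higher numbers stand for weaker inhibition and lower numbers for stronger inhibition. In this assay compound 1 gives only a limit of the assay, > 50000 nM, and no number. Compound 2 `COC(=O)CC/C(C)=C/Cc1c(OC)c(C)c2c(c1OCC#CCN1CCC(C(=O)OC)CC1)C(=O)OC2` likewise stops at the limit > 50000 nM in this assay. Compound 3 `COC(=O)CC/C(C)=C/Cc1c(OC)c(C)c2c(c1OCC#CCN1CCN(C(c3ccccc3)c3ccc(Cl)cc3)CC1)C(=O)OC2` also reaches only the limit > 50000 nM in this assay. Within the data shown here, all three values therefore sit together at the limit of > 50000 nM in this assay, at which 3 of the 3 values shown sit, so no step between measured compounds can be sized. Compound 4 `COC(=O)CC/C(C)=C/Cc1c(OC)c(C)c2c(c1OCC#CCN1CCN(Cc3ccc(Cl)cc3)CC1)C(=O)OC2` has not yet been measured; it differs from compound 1 by 4-chlorobenzyl in place of 4-methylphenyl on an amine nitrogen in a ring. With every measured compound at the limit, the expected step is none beyond the scatter, and compound 4 is estimated to give 60000 nM, within 20000 nM to 200000 nM, so that the step that the limit leaves unreadable from compound 1 to compound 4 is expected to leave it at the limit as well.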

Compound 4, half-maximal inhibitory concentration: > 50000 nM
Compound 4: only a limit was reported; the forecaster's own chance of this, stated with the estimate: 85%; the middle value lies beyond the limit too.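

In this assay compound 4 gives > 50000 nM as a limit of the assay and no number. The steps to it from compound 1 and compound 3 therefore cannot be read. The compounds shown leave open whether any group on the ring amine nitrogen would give a measurable value in this assay at all.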